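Nitro for methoxy in a series held at the assay limit

This account rests on a few compounds, and the source may have more. Where it says the series, first, only, none or still open, it means among the compounds named here.

Compound 1 `COc1cccc(-c2nc3c(c(C)nn3-c3ccccc3)c(-c3ccccc3O)c2C#N)c1` is one of three compounds of the shared core measured in an ADME assay on BJ cells (Homo sapiens) for cytotoxicity, with a stated time of 72 h; on this read-out lower numbers stand for an effect already at smaller amounts and higher numbers for an effect only at larger amounts of compound. In this assay compound 1 gives > 23000 nM, which is a limit of the assay and not a number. Compound 2 `CCc1ccc(-c2nc3c(c(C)nn3-c3ccccc3)c(-c3ccccc3C(F)(F)F)c2C#N)cc1` also stands at a limit, giving > 20000 nM in this assay. Compound 3 `CCc1ccc(-c2nc3c(c(C)nn3-c3ccccc3)c(-c3ccccc3)c2C#N)cc1` stands at a limit as well, giving > 20000 nM in this assay. Compound 1 therefore sits where the whole series sits: on (the limit of > 23000 nM in this assay, at which 1 of the 3 values shown sits), while the other two sit on (the limit of > 20000 nM in this assay, at which 2 of the 3 values shown sit).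

Compound 4 `Cc1nn(-c2ccccc2)c2nc(-c3ccc([N+](=O)[O-])cc3)c(C#N)c(-c3ccccc3O)c12` is not yet measured. It differs from compound 1 by 4-nitrophenyl in place of 3-methoxyphenyl on an aromatic carbon. Among the compounds with values here, the only single-place step measured so far is a step that the two limits leave unreadable from compound 2 to compound 3, made at a different position and of unreadable size. Within the data shown here, no measured step touches the position changed here or either of the exchanged groups, and no measured value gives a number to anchor a shift. Given that compound 1 gives > 23000 nM in this assay, the step that the limit leaves unreadable from compound 1 to compound 4 is expected to stay within the scatter. Compound 4 is estimated at 25000 nM, in the range 9000 nM to 70000 nM, and is expected most likely to be reported again only as a limit.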

Compound 4, half-maximal effective concentration: > 20000 nM
Compound 4: no number, only a limit (the forecaster's own chance of this, stated with the estimate: 75%); the middle value does not contradict the limit.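

Compound 1 and compound 4 both stand at limits in this assay, so the step between them, 4-nitrophenyl in place of 3-methoxyphenyl, cannot be read. The compounds shown leave open at what concentration any of them would show an effect, and whether any change on the shared core would shift that concentration.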